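Swapping isopropyl for propyl in an antiproliferative pair

A few compounds are considered here, and "the series" means these few. Any claim that something is new, unique, unknown or untested is made for them only; others in the source may bear on it.

Within the data shown here, in a functional assay on HT-29 cells (Homo sapiens) for antiproliferative activity, read by sulforhodamine B assay (on this read-out higher numbers stand for weaker inhibition and lower numbers for stronger inhibition), compound 2 `CC(C)/C(=N\Nc1nc2ccccc2o1)c1ccccn1` gives 645 nM, the lower of the two numbers measured so far. The other number belongs to compound 1 `c1ccc(/C(=N/Nc2nc3ccccc3o2)C2CC2)nc1`, which gives 20600 nM. Compound 3 `CCC/C(=N\Nc1nc2ccccc2o1)c1ccccn1` differs from compound 2 in one place: propyl in place of isopropyl on a carbon with a double bond to nitrogen, with propyl in place of isopropyl on a carbon with a double bond to nitrogen. Among the measured compounds shown here, the only measured step at this place is a 32-fold lower number from compound 1 to compound 2 (1.50 log units; beyond the scatter), which is large and shows that the group here can matter a great deal. That step exchanged a ring for an open chain, whereas neither group in the new change has a ring. One step is thin guidance, but a smaller shift towards a somewhat higher number seems likely. The estimated change is a 1.4-fold higher number from compound 2 to compound 3 (0.14 log units; within the scatter). For compound 3 the expected value is 900 nM, with an estimated range from 200 nM to 5000 nM.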

Compound 3, half-maximal inhibitory concentration: 851 nM
Compound 3: middle estimate off by 1.1-fold (0.02 log units), on the high side; measured number inside the range.
By their numbers in this assay, from the lowest: compounds 2 and 3 (each within the scatter of the next); then compound 1.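

In this assay, isopropyl and propyl, two open chains with the same count of carbon atoms, cannot be told apart at this position: a 1.3-fold higher number from compound 2 to compound 3 (0.12 log units; within the scatter). The large gap is seen again with a second open chain, a 24-fold lower number from compound 1 to compound 3 (1.38 log units; beyond the scatter), so among these three compounds cyclopropyl alone stands apart, and rearranging the open chain from isopropyl to propyl leaves the number within the usual scatter. No measurement here accounts for why compound 1 differs from the other two.

From the compounds shown here alone, three groups give little to go on, and whether a shorter chain such as methyl or a longer one such as butyl would stay close to compound 2 and compound 3 remains open. So does the outcome of putting an amine or a phenyl ring on this carbon.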